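The compounds below may be only part of what the source reports. "The series", "measured", "known", "first", "only" and "open" are said of these compounds alone.

Notes on the series in a functional assay on EKVX cells (Homo sapiens) for inhibition, read by sulforhodamine B assay, with a stated time of 48 h; on this read-out higher numbers stand for lower toxicity in this test and lower numbers for higher toxicity in this test. Among the measured compounds shown here, compound 2 `Nc1cc(N)c2nc(-c3ccccc3)c(NCc3ccc(F)cc3)nc2c1` is the only member with a number: in this assay compound 2 gives 8710 nM. Compound 1 `COc1ccc(CNc2nc3cc(N)cc(N)c3nc2-c2ccccc2)cc1OC` carries only a limit of the assay; in this assay compound 1 gives < 100000 nM, which is a limit and not a number. The step that the limit leaves unreadable from compound 1 to compound 2 is accordingly unreadable, as the limit of < 100000 nM in this assay, at which 1 of the 2 values shown sits, shows. Compound 3 `Nc1cc(N)c2nc(-c3ccccc3)c(Sc3ccc(F)cc3)nc2c1` is not yet measured. It differs from compound 2 by (4-fluorophenyl)sulfanyl in place of (4-fluorobenzyl)amino on an aromatic carbon. For the measured compounds named here, no measured step touches this exchange: the one recorded step swaps the aryl group on the saturated chain carbon bound to the ring nitrogen, its size cannot be read, and it gives no guide to trading the (4-fluorobenzyl)amino group for (4-fluorophenyl)sulfanyl with its loss of the single hydrogen-bond donor. The expectation therefore rests on the one number shown. For compound 3 the expected step is a 1.4-fold higher number from compound 2 to compound 3 (0.14 log units; within the scatter), not beyond the scatter in either direction. Compound 3 is estimated at 12000 nM, expected to fall between 2500 nM and 60000 nM.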

Compound 3, concentration lethal to 50% of the cells: 83200 nM
Compound 3: middle estimate off by 6.9-fold (0.84 log units), on the low side; measured number outside the range, above it.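

In this assay, the aromatic carbon next to the ring nitrogen and ortho to a phenyl group proves sensitive to its substituent, with (4-fluorophenyl)sulfanyl in place of (4-fluorobenzyl)amino giving a 9.6-fold higher number from compound 2 to compound 3 (0.98 log units; beyond the scatter). Among the compounds shown here, this is the first step whose size can be read, and it lies beyond the scatter, so compound 3 shows lower toxicity in this test than compound 2. The exchange removes the hydrogen-bond donor, the saturated chain carbon and the nitrogen link in one move, so this single step does not show which of these changes carries the shift.

A group such as (4-fluorobenzyl)sulfanyl or 4-fluoroanilino at this position would separate the loss of the nitrogen link from the loss of the saturated chain carbon, and the compounds shown leave that split open, along with any reading of an ether oxygen link. Compound 1 stays a limit and not a number, so its step still cannot be read and the effect of the aryl group on the chain stays open: the limit of < 100000 nM in this assay, at which 1 of the 3 values shown sits.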